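The compounds below may be only part of what the source reports. "The series", "measured", "known", "first", "only" and "open" are said of these compounds alone.

Measured in a functional assay on SW480 cells (Homo sapiens) for cytotoxicity, read by MTT assay, with a stated time of 48 h; on this read-out higher numbers stand for weaker inhibition and lower numbers for stronger inhibition:
Compound 1 `COc1cc([C@@H]2C[C@]2(CO)C(=O)Nc2ccccc2Cl)cc(OC)c1OC` - 13200 nM
Compound 2 `COc1cc([C@H]2C[C@@]2(CO)C(=O)Nc2ccccc2)cc(OC)c1OC` - > 100000 nM (a limit)

Compound 2 gives only a limit, > 100000 nM, and no number. Compound 3 `COc1cc([C@@H]2C[C@]2(CO)C(=O)Nc2ccccc2)cc(OC)c1OC` is the mirror image of compound 2, and the change is the two compounds have the same atoms and bonds and differ only in configuration as drawn: 2 of 2 stereo elements differ (all stereocentres are inverted: mirror images); a stereocentre at a saturated ring carbon is drawn R in compound 2 and S in compound 3; a stereocentre at a saturated ring carbon is drawn R in compound 2 and S in compound 3. The expected direction in this assay is towards stronger inhibition, but a limit cannot fix the size of the step. This expectation leans on compound 1, which gives a real number, 13200 nM. The estimated step is an at least 2.5-fold lower number from compound 2 to compound 3 (0.39 log units; beyond the scatter). For compound 3 the estimate is 40000 nM, with an expected range from 10000 nM to 100000 nM.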

Compound 3, half-maximal inhibitory concentration: 33300 nM
Compound 3: the middle estimate sits 1.2-fold (0.08 log units) above what was measured; the range from low to high includes it.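

In this assay the mirror-image pair shows that configuration alone shifts the read-out, with an at least 3.0-fold lower number from compound 2 to compound 3 (0.47 log units; beyond the scatter), and nothing else separates the two compounds: the fact that compounds 2 and 3 differ only in the configuration as drawn

Compound 2 gives only a limit, > 100000 nM.

Within the configuration of compound 3, the aromatic chloro group also counts, as hydrogen in its place gives a 2.5-fold higher number from compound 1 to compound 3 (0.40 log units; beyond the scatter).

As far as these compounds go, it remains open whether the chloro step holds in the opposite configuration, and how a fluoro or nitrile group on that aromatic carbon would read.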